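This account rests on a few compounds, and the source may have more. Where it says the series, first, only, none or still open, it means among the compounds named here.

Measured compounds:
Compound 1, `COc1ccn2c(-c3ccc(NC(=O)c4ccc([N+](=O)[O-])o4)cc3C)cnc2c1`, gives 640 nM.
Compound 2, `COc1ccn2c(-c3ccc(NC(=O)c4ccc([N+](=O)[O-])o4)c(C)c3)cnc2c1`, gives 430 nM.
Compound 3, `Cc1cc(-c2cnc3ccccn23)ccc1NC(=O)c1ccc([N+](=O)[O-])o1`, gives 730 nM.

All three were tested in a functional assay on AGS cells (Homo sapiens) for antiproliferative activity, read by CCK-8 assay, with a stated time of 72 h; on this read-out higher numbers stand for weaker inhibition and lower numbers for stronger inhibition. Compound 1 and compound 2 are built from the same atoms joined differently; the difference between the two cores is not broken down here. From compound 2 to compound 3 a single change is made: hydrogen in place of methoxy on an aromatic carbon. That change produced a 1.7-fold higher number from compound 2 to compound 3 (0.23 log units; within the scatter). The values of compound 1 and compound 3 lie within the scatter of each other, so no order is read between them.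

Compound 4, `Cc1cc(NC(=O)c2ccc([N+](=O)[O-])o2)ccc1-c1cnc2ccccn12`, is not yet measured. It differs from compound 1 by the same change at the same place: hydrogen in place of methoxy on an aromatic carbon. Among the compounds with values here, because the one measured instance of this change gave a 1.7-fold higher number from compound 2 to compound 3 (0.23 log units; within the scatter), a step of similar size is expected in this assay: a 1.6-fold higher number from compound 1 to compound 4 (0.19 log units; within the scatter). This rests on a single pair, so the expectation is loose. On that basis compound 4 is estimated at 1000 nM, with a range from 450 nM to 2300 nM.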

Compound 4, half-maximal inhibitory concentration: 390 nM
Beside the measured number, compound 4's estimate is 2.6-fold (0.41 log units) above it; measured number below the stated range.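

In this assay, replacing methoxy with hydrogen gives a 1.6-fold lower number from compound 1 to compound 4 (0.22 log units; within the scatter), and this step does not carry over from the other core in size or direction: the same change on two cores in this assay, a 1.7-fold higher number (0.23 log units; within the scatter) from compound 2 to compound 3 and a 1.6-fold lower number (0.22 log units; within the scatter) from compound 1 to compound 4, 2.8-fold (0.44 log units) apart, beyond the scatter of two such steps

Each step taken alone lies within the scatter, so neither pair by itself establishes an effect of the change; only the gap between the two steps lies beyond it. The two pairs show that a step measured on one of these cores cannot be applied unchanged to the other, but they do not show what sets the gap or how the change would behave on any further core.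

The compounds shown carry only methoxy or hydrogen at this place, so the outcome with fluorine, chlorine, an amine or a longer chain such as ethoxy remains open. Going by these compounds, whether such groups would also give steps that differ between the two cores is equally open.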